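Amide Variation on a Shared Core: Expectation for Compound 4

The compounds below may be only part of what the source reports. "The series", "measured", "known", "first", "only" and "open" are said of these compounds alone.

Measured compounds:
compound 1, `CCOC(=O)c1c(O)c2cccnc2n(-c2ccccc2)c1=O`: in a functional assay on the whole organism for inhibition, with Rattus norvegicus as the target, read by paw edema, at a dose of 100 mg/kg by the oral route (on this read-out higher numbers stand for more inhibition at the one dose given (going by the name of the read-out) and lower numbers for less inhibition), compound 1 gives 23.5%
compound 2, `O=C(NCc1ccccc1)c1c(O)c2cccnc2n(-c2ccccc2)c1=O`: compound 2 gives 1.6%
compound 3, `O=C(NCc1cccnc1)c1c(O)c2cccnc2n(-c2ccccc2)c1=O`: compound 3 gives 25.5%

Compound 3 holds the largest of the three numbers, but it cannot be set apart from compound 1, since a number 2 percentage points higher from compound 1 to compound 3 (within the scatter). Its separation from compound 2 is real: a number 23.9 percentage points higher from compound 2 to compound 3 (beyond the scatter).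

Compound 4, `O=C(Nc1ccc(Cl)nc1)c1c(O)c2cccnc2n(-c2ccccc2)c1=O`, differs from compound 3 in one place: 6-chloropyridin-3-yl in place of (pyridin-3-yl)methyl on an amide-type nitrogen. Within the data shown here, no measured step removes the saturated chain carbon or adds a chlorine, so the available evidence is indirect. The step of a number 23.9 percentage points higher from compound 2 to compound 3 (beyond the scatter) shows that a pyridin-3-yl ring in this region gave a markedly larger number than phenyl, which compound 4 keeps in a chlorinated form. The steps of a number 21.9 percentage points lower from compound 1 to compound 2 (beyond the scatter) and a number 2 percentage points higher from compound 1 to compound 3 (within the scatter) show that amides on this carbonyl can fall well below the ester or match it. Given the uncertainty, a small fall is expected for compound 4: a number 10.5 percentage points lower from compound 3 to compound 4 (beyond the scatter). Compound 4 is therefore estimated at 15%, within a range from 0% to 35%.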

Compound 4, a percentage reported as inhibition, in the whole organism at one dose (the size of the read-out at that dose, not a potency): 9.2%
Compound 4: middle estimate off by 5.8 percentage points, on the high side, and the stated range covers the measured number.
By their numbers in this assay, from the lowest: compounds 2 and 4 (each within the scatter of the next); then compounds 1 and 3 (each within the scatter of the next).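

In this assay, 6-chloropyridin-3-yl in place of (pyridin-3-yl)methyl on the amide-type nitrogen gives a number 16.3 percentage points lower from compound 3 to compound 4 (beyond the scatter), so a pyridine ring in this region does not by itself hold the number of compound 3. Measured against the ester, the change gives a number 14.3 percentage points lower from compound 1 to compound 4 (beyond the scatter), and measured against the benzyl amide it gives a number 7.6 percentage points higher from compound 2 to compound 4 (within the scatter), which places this chlorinated amide level with the benzyl amide rather than with the ester. No measured property bears on this result.

As far as these compounds go, this single step both removes the saturated chain carbon and adds a chlorine, so the share of each in the fall stays open. A pyridin-3-yl carried directly on that nitrogen without chlorine, or a longer 2-(pyridin-3-yl)ethyl chain, would begin to separate the two changes.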